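Amine variation at the pyridine of the propanamide series

The compounds below may be only part of what the source reports. "The series", "measured", "known", "first", "only" and "open" are said of these compounds alone.

Measured compounds:
compound 1, `CCCCNc1nc(C(F)(F)F)ccc1CNC(=O)C(C)c1ccc(NS(C)(=O)=O)c(F)c1`, 9.1 nM
compound 2, `CC(C(=O)NCc1ccc(C(F)(F)F)nc1N(C)C)c1ccc(NS(C)(=O)=O)c(F)c1`, 19.1 nM
compound 3, `CC(C(=O)NCc1ccc(C(F)(F)F)nc1N1CCCCC1C)c1ccc(NS(C)(=O)=O)c(F)c1`, 2.9 nM

All three were run in a functional assay on CHO-K1 cells for antagonist activity at transient receptor potential cation channel subfamily V member 1 (Homo sapiens), read by FLIPR; a higher number here means a weaker inhibitor, a lower number a stronger inhibitor. Among them compound 3 gives the lowest number: compound 1 is the nearest, and the gap a 3.1-fold lower number from compound 1 to compound 3 (0.50 log units; beyond the scatter) lies beyond the scatter, while compound 2 is the furthest, with a 6.6-fold lower number from compound 2 to compound 3 (0.82 log units; beyond the scatter). The two acyclic amines differ from each other only modestly, a 2.1-fold higher number from compound 1 to compound 2 (0.32 log units; beyond the scatter).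

Compound 4, `COC1CCN(c2nc(C(F)(F)F)ccc2CNC(=O)C(C)c2ccc(NS(C)(=O)=O)c(F)c2)CC1`, has not been measured. It differs from compound 3 in one place: 4-methoxypiperidin-1-yl in place of 2-methylpiperidin-1-yl on an aromatic carbon. The measured steps that bear on this are those into compound 3 from the acyclic amines, a 3.1-fold lower number from compound 1 to compound 3 (0.50 log units; beyond the scatter) and a 6.6-fold lower number from compound 2 to compound 3 (0.82 log units; beyond the scatter), both of which lowered the number on arrival at the cyclic amine. Within the data shown here, no measured pair compares two cyclic amines with each other, so the size of the present step has no direct precedent. Since compound 4 keeps a six-membered ring of the same kind, the number is expected to stay in the lower part of the range seen, with some rise from compound 3 allowed. The step of a 2.1-fold higher number from compound 3 to compound 4 (0.32 log units; beyond the scatter) is the expected change. For compound 4 the estimate in this assay is 6 nM, with a range from 2 nM to 18 nM.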

Compound 4, inhibition constant: 2.4 nM
For compound 4 the middle estimate is 2.5-fold (0.40 log units) above the measured one, within the range that was stated.
By their numbers in this assay, from the lowest: compounds 4 and 3 (each within the scatter of the next); then compound 1; then compound 2.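

In this assay, among these compounds, the step of a 1.2-fold lower number from compound 3 to compound 4 (0.08 log units; within the scatter) gives the first comparison of two cyclic amines on this aromatic carbon next to the ring nitrogen, and it leaves the two compounds indistinguishable even though 4-methoxypiperidin-1-yl carries an extra oxygen and its substituent is placed differently on the ring. The 4-methoxypiperidin-1-yl group also stands clear of both acyclic amines in the steps of an 8.0-fold lower number from compound 2 to compound 4 (0.90 log units; beyond the scatter) and a 3.8-fold lower number from compound 1 to compound 4 (0.58 log units; beyond the scatter), so among the four compounds both piperidines give lower numbers than the butylamino and dimethylamino compounds, and none goes against this. No supporting measurement bears on why these numbers fall as they do.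

Since the 2-methyl and 4-methoxy groups differ in both kind and ring position, these compounds cannot separate the two changes, and 4-methylpiperidin-1-yl or 2-methoxypiperidin-1-yl would be needed to do so. Also open, on these data alone, is how an unsubstituted piperidine, a pyrrolidine, a morpholine or a piperidine bearing a carboxylic acid would behave at this position.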